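Replacing 3-aminophenyl with 4-methylphenyl on the shared core

The source may hold more compounds than are shown below. What is called first, only, known or untested is meant among the compounds shown, and "the series" means these compounds.

compound 1 `CCOc1ccc(-c2ccc3ncn(-c4cc(OC)c(OC)c(OC)c4)c3c2)cc1` gives 2970 nM
compound 2 `COc1cc(-n2cnc3ccc(-c4ccccc4)cc32)cc(OC)c1OC` gives 290 nM
compound 3 `COc1cc(-n2cnc3ccc(-c4cccc(N)c4)cc32)cc(OC)c1OC` gives 21 nM

In a functional assay on SGC-7901 cells (Homo sapiens) for antiproliferative activity, read by MTT assay, with a stated time of 72 h (a lower number here means a stronger inhibitor, a higher number a weaker inhibitor), compound 3 has the lowest number of the three, and its steps to both of the others lie beyond the scatter. The change now in view is 4-methylphenyl in place of 3-aminophenyl on an aromatic carbon. It gives compound 4 `COc1cc(-n2cnc3ccc(-c4ccc(C)cc4)cc32)cc(OC)c1OC`, with 4-methylphenyl in place of 3-aminophenyl on an aromatic carbon.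

Among the measured compounds shown here, three measured steps bear on this change. Amino in place of hydrogen came with a 14-fold lower number from compound 2 to compound 3 (1.14 log units; beyond the scatter), and compound 4 has no amino group. Compound 1 carries 4-ethoxyphenyl, the closest match to 4-methylphenyl among the measured compounds, and the swap to 3-aminophenyl came with a 140-fold lower number from compound 1 to compound 3 (2.15 log units; beyond the scatter). Hydrogen in place of ethoxy came with a 10-fold lower number from compound 1 to compound 2 (1.01 log units; beyond the scatter), so the group on that phenyl ring also mattered in this small set. Compound 4 would therefore be expected to lose the gain seen with the amino group and to fall between compound 2 and compound 1.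

The expected change is large, towards a higher number and beyond the scatter, and is estimated as a 33-fold higher number from compound 3 to compound 4 (1.52 log units; beyond the scatter). For compound 4 the estimated value is 700 nM, with an expected range from 200 nM to 2500 nM.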

Compound 4, half-maximal inhibitory concentration: 200 nM
Beside the measured number, compound 4's estimate is 3.5-fold (0.54 log units) above it, and the stated range covers the measured number.
By their numbers in this assay, from the lowest: compound 3; then compounds 4 and 2 (each within the scatter of the next); then compound 1.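

In this assay, 4-methylphenyl in place of 3-aminophenyl came with a 9.5-fold higher number from compound 3 to compound 4 (0.98 log units; beyond the scatter) and left compound 3 with the lowest number of the four, its steps to all the others lying beyond the scatter. Methyl in place of hydrogen came with a 1.5-fold lower number from compound 2 to compound 4 (0.16 log units; within the scatter) and thus no readable change, so at this position a methyl group on the phenyl ring cannot be told apart from the unsubstituted phenyl. Methyl in place of ethoxy came with a 15-fold lower number from compound 1 to compound 4 (1.17 log units; beyond the scatter) as its result, which shows that the high number of compound 1 goes with the ethoxy group and does not extend to every group on that phenyl ring. Nothing shown here gives a measured reason for these differences.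

The compounds shown leave open whether the gain belongs to the amino group alone or also to its place on the ring, a question that 4-aminophenyl would address. They also leave open whether a hydroxyl group or a dimethylamino group at the place of the amino group would keep the low number of compound 3.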